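The compounds below may be only part of what the source reports. "The series", "measured", "known", "first", "only" and "open" are said of these compounds alone.

In an ADME assay on MRC5 cells (Homo sapiens) for inhibition, read by MTT assay, with a stated time of 72 h (on this read-out lower numbers stand for stronger inhibition and higher numbers for weaker inhibition), compound 3 `O=C(OCCCCCCCCOC(=O)OCCc1ccc(O)c(O)c1)OCCc1ccc(O)c(O)c1` gives > 50000 nM, which is a limit of the assay and not a number. Compound 2 `O=C(OCCCCCCO)OCCc1ccc(O)c(O)c1` gives > 50000 nM, which is likewise a limit and not a number. Compound 2 therefore stands at the limit of > 50000 nM in this assay, at which 2 of the 3 values shown sit, and it has no exact position on the scale. Compound 1 `O=C(OCCCCCCCCOC(=O)OCCc1ccc(OCc2ccccc2)c(OCc2ccccc2)c1)OCCc1ccc(OCc2ccccc2)c(OCc2ccccc2)c1` adds nothing to this picture, since its entry reads "not determined" (no result reported).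

The next compound to be tested in this assay is compound 4 `CCCCCCOC(=O)OCCc1ccc(O)c(O)c1`. Its structure departs from that of compound 2 in one place: hydrogen in place of hydroxy on a saturated chain carbon, six bonds along the chain from an oxygen next to a carbonyl group. In words, hydrogen takes the place of hydroxy on a saturated chain carbon, six bonds along the chain from an oxygen next to a carbonyl group, so that hydroxymethyl becomes methyl.

Among the measured compounds shown here, no pair of measured compounds shows what this change does. The expectation therefore rests on compound 2, whose > 50000 nM is a limit. The step expected an at least 1.2-fold lower number from compound 2 to compound 4 (0.09 log units; that floor lies within the scatter) is small and points, if anywhere, towards stronger inhibition, and the assay may well return only a limit again. For compound 4 the estimated value is 40000 nM, with an expected range of 15000 nM to 90000 nM.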

Compound 4, half-maximal inhibitory concentration: 11200 nM
Estimate against measurement, compound 4: 3.6-fold (0.55 log units) above, and the stated range ends above it.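

In this assay, hydrogen in place of hydroxy on a saturated chain carbon, six bonds along the chain from an oxygen next to a carbonyl group, turns hydroxymethyl into methyl and gives an at least 4.4-fold lower number from compound 2 to compound 4 (0.64 log units; beyond the scatter). This is the first sign among the compounds shown that this end of the chain matters for the read-out, and the step towards stronger inhibition lies beyond the usual scatter, with compound 4 the first of them to give a number and not a limit. The value of compound 2 is a limit and not a number, so the step is only a floor and its full size stays unknown: the limit of > 50000 nM in this assay, at which 2 of the 4 values shown sit.

The compounds shown leave open whether a longer chain ending in methyl, or an amine or a carboxylic acid in place of the hydroxy, would push the number lower still or return it to the limit. On these data alone, one pair alone carries this change, and whether the same exchange on a chain of another length gives a step of like size also remains open.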